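Bromo in place of hydrogen on the core of compound 2

The source may hold more compounds than are shown below. What is called first, only, known or untested is meant among the compounds shown, and "the series" means these compounds.

Measured compounds:
compound 1 `COc1ccc(/C(Cl)=C/C=C(\C#N)C(=O)c2c[nH]c3ccc(Br)cc23)cc1`, 56.2%
compound 2 `N#C/C(=C\C=C(/Cl)c1ccc(Br)cc1)C(=O)c1c[nH]c2ccccc12`, 76.7%

In a functional assay for inhibition, read by Griess assay, with a stated time of 150 min, tested at 1 mM (on this read-out higher numbers stand for more inhibition at the one concentration tested (going by the name of the read-out) and lower numbers for less inhibition), compound 2 gives 76.7%, the highest of the two numbers; compound 1 gives 56.2%, lower by a margin beyond the scatter. Among the compounds with values here, no single-point step connects them. Compound 3 `N#C/C(=C\C=C(/Cl)c1ccc(Br)cc1)C(=O)c1c[nH]c2ccc(Br)cc12` differs from compound 2 by bromo in place of hydrogen on an aromatic carbon. Within the data shown here, no measured step of this kind exists here, so the step from compound 2 to compound 3 is expected to stay within the scatter, if anything slightly downward: a number 6.7 percentage points lower from compound 2 to compound 3 (within the scatter). Compound 3 is therefore estimated at 70%, between 48% and 88%.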

Compound 3, a percentage reported as inhibition, at one concentration (the size of the read-out at that concentration, not a potency): 67.5%
Compound 3: middle estimate off by 2.5 percentage points, on the high side, within the range that was stated.
By their numbers in this assay, from the lowest: compound 1; then compounds 3 and 2 (each within the scatter of the next).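

In this assay, bromo in place of hydrogen on an aromatic carbon of the core gives a number 9.2 percentage points lower from compound 2 to compound 3 (within the scatter), so the read-out does not separate hydrogen from bromo at this position. Bromo in place of methoxy on an aromatic carbon of the other ring, with bromo kept on the core, gives a number 11.3 percentage points higher from compound 1 to compound 3 (beyond the scatter), a modest step beyond the scatter. Nothing available explains either step. Open, going by these compounds, is how an amine or a carboxylic acid at the core position would read, and whether hydrogen in place of methoxy would give a comparable step.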